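This account rests on a few compounds, and the source may have more. Where it says the series, first, only, none or still open, it means among the compounds named here.

Compound 1 `Cc1ccc(-n2cc(-c3ccc(CN4CCN(C)CC4)c(C(F)(F)F)c3)nn2)cc1Nc1nccc(-c2cccnc2)n1` carries a (4-methylpiperazin-1-yl)methyl group and in a functional assay on HL-60 cells (Homo sapiens) for inhibition, read by MTT assay, with a stated time of 72 h (on this read-out higher numbers stand for weaker inhibition and lower numbers for stronger inhibition), compound 1 gives 20 nM. For compound 2 `Cc1ccc(-n2cc(-c3ccc(C)c(C(F)(F)F)c3)nn2)cc1Nc1nccc(-c2cccnc2)n1` this assay reports only a limit, > 30000 nM. The change hydrogen in place of 4-methylpiperazin-1-yl on a saturated chain carbon bound to an aromatic carbon thus produced an at least 1500-fold higher number from compound 1 to compound 2 (3.17 log units; beyond the scatter), a step that runs into (the limit of > 30000 nM in this assay, at which 1 of the 3 values shown sits).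

Compound 3 `Cc1ccc(-c2nnc(-c3ccc(CN4CCN(C)CC4)c(C(F)(F)F)c3)o2)cc1Nc1nccc(-c2cccnc2)n1` has a different core; the difference between the two cores is not broken down here. In this assay compound 3 gives 50 nM.

Compound 4 `Cc1ccc(-c2nnc(-c3ccc(C)c(C(F)(F)F)c3)o2)cc1Nc1nccc(-c2cccnc2)n1` is not yet measured. It differs from compound 3 by hydrogen in place of 4-methylpiperazin-1-yl on a saturated chain carbon bound to an aromatic carbon, the same change as from compound 1 to compound 2, at the same place. The expected step is a 600-fold higher number from compound 3 to compound 4 (2.78 log units; beyond the scatter), resting on the earlier step of an at least 1500-fold higher number from compound 1 to compound 2 (3.17 log units; beyond the scatter) and on (the limit of > 30000 nM in this assay, at which 1 of the 3 values shown sits). Compound 4 is therefore estimated at 30000 nM, expected within 3000 nM to 100000 nM, with a limit the likely outcome.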

Compound 4, half-maximal inhibitory concentration: > 30000 nM
Compound 4 gave a limit, no number; the forecaster's own chance of this, stated with the estimate: 70%; the middle value lies on the limit itself.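

In this assay, the change from (4-methylpiperazin-1-yl)methyl to methyl carries over to the core of compound 3 in the same direction, giving an at least 600-fold higher number from compound 3 to compound 4 (2.77 log units; beyond the scatter). Compound 4 gives > 30000 nM, which is a limit of the assay and not a number. The two cores therefore agree that the loss is large, but the size of the loss on each core stays unknown, and no difference between the cores can be read: the same change on two cores in this assay, an at least 1500-fold higher number (3.17 log units; beyond the scatter) from compound 1 to compound 2 and an at least 600-fold higher number (2.77 log units; beyond the scatter) from compound 3 to compound 4; the limit leaves it open whether they differ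

The compounds shown cover only these two groups at this place, on two cores. Going by these compounds, whether a morpholine or a dimethylamine on the same carbon, or a longer chain carrying the 4-methylpiperazine, would retain the inhibition seen with compound 1 and compound 3 remains open.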